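Swapping a para chloro for bromo on a shared thiazepinone core

The compounds below may be only part of what the source reports. "The series", "measured", "known", "first", "only" and "open" are said of these compounds alone.

Of the compounds shown here, three with a common core have been tested in a functional assay on MOLT-4 cells (Homo sapiens) for cytotoxicity, read by CCK-8 assay, with a stated time of 24 h; on this read-out higher numbers stand for weaker inhibition and lower numbers for stronger inhibition. Compound 1 `C=CC(=O)N1C(=O)CC(c2ccc(OC)cc2)Sc2ccccc21` gives 83200 nM. Compound 2 `C=CC(=O)N1C(=O)CC(c2ccccc2Cl)Sc2ccccc21` gives 80300 nM. Compound 3 `C=CC(=O)N1C(=O)CC(c2ccc(Cl)cc2)Sc2ccccc21` gives 82400 nM. The three numbers sit so close together that none can be set apart: the steps of a 1.0-fold lower number from compound 1 to compound 2 (0.02 log units; within the scatter), a 1.0-fold lower number from compound 1 to compound 3 (0.00 log units; within the scatter) and a 1.0-fold higher number from compound 2 to compound 3 (0.01 log units; within the scatter) all stay within the scatter, so compound 3 stands among equals, its nearest neighbour being compound 1 and its furthest compound 2, both within the scatter.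

Compound 4 `C=CC(=O)N1C(=O)CC(c2ccc(Br)cc2)Sc2ccccc21` differs from compound 3 only in that a (bromo in place of chloro on an aromatic carbon). Among the measured compounds shown here, no measured step swaps one halogen for another at this position. The closest guide is the step from compound 1 to compound 3, a 1.0-fold lower number from compound 1 to compound 3 (0.00 log units; within the scatter), where a different group at the same aromatic carbon changed nothing, and the step of a 1.0-fold higher number from compound 2 to compound 3 (0.01 log units; within the scatter), where moving the chloro around the ring also changed nothing. The expectation is therefore a step of a 1.0-fold lower number from compound 3 to compound 4 (0.00 log units; within the scatter), none beyond the scatter. Compound 4 is estimated at 82000 nM, between 41000 nM and 164000 nM.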

Compound 4, half-maximal inhibitory concentration: 106000 nM
The estimate for compound 4 lay 1.3-fold (0.11 log units) below the measured number; measured number inside the range.
By their numbers in this assay, from the lowest: compounds 2, 3, 1 and 4 (each within the scatter of the next).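

In this assay, among the compounds shown here, the first direct swap of one halogen for another on this aromatic carbon (a 1.3-fold higher number from compound 3 to compound 4 (0.11 log units; within the scatter)) stays within the scatter, so 4-chlorophenyl and 4-bromophenyl cannot be told apart here. The comparisons with the other two compounds (a 1.3-fold higher number from compound 2 to compound 4 (0.12 log units; within the scatter); a 1.3-fold higher number from compound 1 to compound 4 (0.11 log units; within the scatter)) also stay within the scatter, so bromo joins methoxy and chloro as groups on this ring that leave all four compounds level. Nothing measured here offers a reason for this evenness.

From the compounds shown here alone, whether an amine or a carboxylic acid on this aromatic carbon would give a number beyond the scatter remains open. Also open, going by these compounds, is whether a change elsewhere on the shared core would separate compounds that this ring position does not.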